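This account rests on a few compounds, and the source may have more. Where it says the series, first, only, none or still open, it means among the compounds named here.

Of the compounds shown here, three have been measured in a functional assay on the whole organism (Tail, strain ICR) with Mus musculus as the target, in the tail flick test, with a stated time of 120 min, at a dose of 25 umol/kg by the oral route; on this read-out higher numbers stand for a stronger effect at the one dose given and lower numbers for a weaker effect. Compound 1 `O=C(CN(c1ncnc2c1ncn2C1CCCCO1)C1CC1)NCC(=O)OCc1ccccc1` gives 17.2% in this assay. Compound 2 `O=C(OCc1ccccc1)[C@@H]1CCCN1C(=O)CN(c1nc(Cl)nc2[nH]cnc12)C1CC1` gives 38.4% in this assay. Compound 3 `O=C(CN(c1nc(Cl)nc2[nH]cnc12)C1CC1)N[C@@H](CCC(=O)OCc1ccccc1)C(=O)OCc1ccccc1` gives 45.9% in this assay. Of the three numbers, compound 1 stands lowest: compound 2 sits higher by a margin beyond the usual scatter, and compound 3 sits higher still, also beyond the scatter.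

Compound 4 `C[C@H](NC(=O)CN(c1ncnc2c1ncn2C1CCCCO1)C1CC1)C(=O)OCc1ccccc1` has not yet been measured in this assay. It differs from compound 1 in a single place: methyl in place of hydrogen on a saturated chain carbon bound to an amide-type nitrogen and a carbonyl carbon. For the measured compounds named here, no measured pair in this set differs by this kind of change alone, so there is no step here to lean on. The change adds one carbon and nothing else, so the step of a number 4.8 percentage points higher from compound 1 to compound 4 (within the scatter) is expected to be small, probably within the scatter, with a slight lean upward rather than downward. Compound 4 is therefore estimated at 22%, with a range from 8% to 38%.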

Compound 4, a percentage reported as activity, at one dose (the size of the read-out at that dose, not a potency): 25.3%
For compound 4 the middle estimate is 3.3 percentage points below the measured one, within the range that was stated.
By their numbers in this assay, from the lowest: compounds 1 and 4 (each within the scatter of the next); then compounds 2 and 3 (each within the scatter of the next).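

In this assay, methyl in place of hydrogen on a saturated chain carbon bound to an amide-type nitrogen and a carbonyl carbon gives a number 8.1 percentage points higher from compound 1 to compound 4 (within the scatter). This is the only pair shown that differs in one place, and it shows that one added carbon at this position leaves a difference that cannot be told from the scatter at the one dose given. No measurement shown explains this result.

Still open, going by these compounds, is whether a larger group on this same carbon, such as an isopropyl or a benzyl group, or a carboxylic acid or an amine on a longer chain there, would give a difference beyond the scatter. Also open, on these data alone, is whether the mirror-image arrangement of the methyl at this carbon would give a similar number.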